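A few compounds are considered here, and "the series" means these few. Any claim that something is new, unique, unknown or untested is made for them only; others in the source may bear on it.

Compound 1 `COc1ccc(-c2sc(C(=O)O)cc2-c2cc(OC)c(OC)c(OC)c2)cc1` and compound 3 `CCOC(=O)c1cc(-c2ccc(OC)cc2)c(-c2cc(OC)c(OC)c(OC)c2)s1` share a core, and how their cores differ is not broken down here. In a functional assay on HT-1080 cells (Homo sapiens) for antiproliferative activity, read by MTT assay, with a stated time of 72 h (a lower number here means a stronger inhibitor, a higher number a weaker inhibitor), compound 1 gives 6770 nM, and compound 3 gives 7630 nM, two numbers that lie within the usual scatter of each other. Compound 2 `COc1ccc(-c2sc(C(=O)O)cc2-c2cc(OC)c(OC)c(OC)c2)cc1[N+](=O)[O-]` carries nitro in place of hydrogen on an aromatic carbon; that change made a 5.5-fold higher number from compound 1 to compound 2 (0.74 log units; beyond the scatter), leaving compound 2 at 37200 nM. Compound 4 `CCOC(=O)c1cc(-c2ccc(OC)c([N+](=O)[O-])c2)c(-c2cc(OC)c(OC)c(OC)c2)s1` carries the same change on compound 3, namely (nitro in place of hydrogen on an aromatic carbon), at a place described in the same words. Because the first pair showed a 5.5-fold higher number from compound 1 to compound 2 (0.74 log units; beyond the scatter), a step of similar size is expected for the second pair, so the estimated step is a 5.0-fold higher number from compound 3 to compound 4 (0.70 log units; beyond the scatter). On that basis compound 4 is expected to give about 38000 nM, most likely between 15000 nM and 95000 nM.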

Compound 4, half-maximal inhibitory concentration: 26100 nM
Beside the measured number, compound 4's estimate is 1.5-fold (0.16 log units) above it, within the range that was stated.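

In this assay the nitro group gave a 3.4-fold higher number from compound 3 to compound 4 (0.53 log units; beyond the scatter) and so made the inhibitor weaker on this core as well. Set beside the earlier pair, the two steps point the same way and do not differ in size beyond what repeated measurements would give: the same change on two cores in this assay, a 5.5-fold higher number (0.74 log units; beyond the scatter) from compound 1 to compound 2 and a 3.4-fold higher number (0.53 log units; beyond the scatter) from compound 3 to compound 4, 1.6-fold (0.21 log units) apart, within the scatter of two such steps. This shows that the change carried over between these two cores in this one cell assay, but two pairs cannot show that it would carry over to other cores, and they do not explain why the number rises.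

The compounds shown leave open how a different group at the same place on the 4-methoxyphenyl ring, such as an amine, would behave.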